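Changing the outer ring of a shared core

This account rests on a few compounds, and the source may have more. Where it says the series, first, only, none or still open, it means among the compounds named here.

Measured so far:
- Compound 1 `Cc1ccc(NC(=S)NC(=O)c2ccc(OCc3cccc(C(F)(F)F)c3)cc2)cc1-c1nc2ccccc2[nH]1`: in a functional assay on SW-620 cells (Homo sapiens) for inhibition, read by MTT assay, with a stated time of 48 h (on this read-out higher numbers stand for weaker inhibition and lower numbers for stronger inhibition), compound 1 gives 15400 nM.
- Compound 2 `Cc1ccc(NC(=S)NC(=O)c2ccc(OCc3cccc(Cl)c3Cl)cc2)cc1-c1nc2ccccc2[nH]1`: in this assay compound 2 gives only an assay limit, > 100000 nM.

Compound 2 therefore stands at the edge of what this assay can report; its result is a limit, not a number (the limit of > 100000 nM in this assay, at which 1 of the 2 values shown sits). For the measured compounds named here, the single measured step, an at least 6.4-fold higher number from compound 1 to compound 2 (0.81 log units; beyond the scatter), is a weakening whose full size is unknown for the same reason.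

Compound 3 `Cc1ccc(NC(=S)NC(=O)c2ccc(OCc3ccc(F)cc3)cc2)cc1-c1nc2ccccc2[nH]1` has not been measured. It differs from compound 2 by 4-fluorophenyl in place of 2,3-dichlorophenyl on a saturated chain carbon bound to an oxygen on an aromatic ring. Going by the values given here, no measured step touches a 4-fluorophenyl group, so the only anchors are compound 2, whose result is a limit, and compound 1. In this assay compound 1 stands at 15400 nM. Compound 3 is expected to move by an at least 2.5-fold lower number from compound 2 to compound 3 (0.39 log units; beyond the scatter), a gain in inhibition that may again be partly hidden by the limit. Compound 3 is estimated at 40000 nM, with a likely range from 10000 nM to 200000 nM.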

Compound 3, half-maximal inhibitory concentration: 40500 nM
The estimate for compound 3 lay 1.0-fold (0.01 log units) below the measured number; the range from low to high includes it.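

In this assay, the change from 2,3-dichlorophenyl to 4-fluorophenyl gives an at least 2.4-fold lower number from compound 2 to compound 3 (0.39 log units; beyond the scatter) and so shows that inhibition at this position is not simply lost once 3-(trifluoromethyl)phenyl is replaced. The result of compound 2 is a limit and not a number, which leaves that step with only a minimum size: the limit of > 100000 nM in this assay, at which 1 of the 3 values shown sits. For the compounds shown here, compound 3 also gives the first step here with true numbers at both ends, a 2.6-fold higher number from compound 1 to compound 3 (0.42 log units; beyond the scatter) and so 3-(trifluoromethyl)phenyl keeps the stronger inhibition of these two groups.

On these data alone, what remains open is whether the trifluoromethyl group itself or its place on the ring sets compound 1 apart from compound 3. The compounds shown also say nothing about how a nitrile or a methoxy group on this ring would read.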